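A few compounds are considered here, and "the series" means these few. Any claim that something is new, unique, unknown or untested is made for them only; others in the source may bear on it.

Measured in an in vitro ADME assay on microsomes (Mus musculus) for metabolic stability; a higher number here means that the compound lasts longer, a lower number that the compound disappears faster:
Compound 1 `CNC(=O)Nc1ccc(-c2nc(N3CC4CCC(C3)O4)c3cnn(CCN(C)C)c3n2)cc1`: 0.0833 h
Compound 2 `O=C(Nc1ccccc1)Nc1ccc(-c2nc(N3CC4CCC(C3)O4)c3cnn(C4CCC5(CC4)OCCO5)c3n2)cc1`: > 0.5 h

Compound 1 is the short-lived of the two, with a half-life of 0.0833 h. Compound 2 reads > 0.5 h, which is a limit of the assay and not a number. For the measured compounds named here, this is the only such reading among the measured compounds: the limit of > 0.5 h in this assay, at which 1 of the 2 values shown sits. Going by these compounds, compound 2 therefore gives a floor to start from, and its true half-life remains unknown.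

The next compound, compound 3 `O=C(Nc1ccncc1)Nc1ccc(-c2nc(N3CC4CCC(C3)O4)c3cnn(C4CCC5(CC4)OCCO5)c3n2)cc1`, keeps everything in compound 2 except for one group: pyridin-4-yl in place of phenyl on an amide-type nitrogen. In words, this is pyridin-4-yl in place of phenyl on an amide-type nitrogen. Going by the values given here, no measured pair of compounds shows this change, so there is no measured step to go by. The expectation rests on compound 2 alone, whose > 0.5 h is a limit. In this assay, the expected change, an at least 1.1-fold lower number from compound 2 to compound 3 (0.04 log units; that floor lies within the scatter), is estimated to stay within the usual scatter, with no direction favoured. A reading of compound 3 as a limit would also be expected to be quite possible. For compound 3 the estimated half-life is 0.45 h, with an expected range of 0.2 h to 0.9 h.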

Compound 3, half-life: > 0.5 h
Compound 3: no number, only a limit (the forecaster's own chance of this, stated with the estimate: 45%); middle value at least 1.1-fold (0.04 log units) away from the limit.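

In this assay compound 3 gives > 0.5 h, which is a limit of the assay and not a number. Compound 2 also stands at a limit, so no step can be read between compound 2 and compound 3. The compounds shown leave open the true half-life of each, and whether pyridin-4-yl in place of phenyl on an amide-type nitrogen changes it.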